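A few compounds are considered here, and "the series" means these few. Any claim that something is new, unique, unknown or untested is made for them only; others in the source may bear on it.

Working notes on the alkoxyphenyl ketone series. Compound 2 `CCCC(=O)c1ccc(OCCCCOc2ccc(F)c(C(=O)O)c2)c(C)c1O` gives, in an assay on HEK293 cells for positive allosteric modulation of metabotropic glutamate receptor 2 (Rattus norvegicus), read by thallium flux, with a stated time of 2.5 min (a higher number here means a larger maximal response, a lower number a smaller maximal response), a maximal response of 87.5%, the higher of the two numbers in hand; compound 1 `COc1cc(C(=O)O)ccc1OCCCCOc1ccc(C(=O)C(C)C)c(O)c1C` gives 73.1% in this assay, a gap beyond the scatter. Compound 3 `Cc1c(OCCCCOc2ccc(F)c(C(=O)O)c2)ccc(C(=O)CC(C)C)c1O` is not yet measured in this assay. It differs from compound 2 by methyl in place of hydrogen on a saturated chain carbon bound to two saturated chain carbons. Among the compounds with values here, no measured pair shows this change, so the size of the step is open; on the chain alone it is expected to shift little, the step from compound 2 to compound 3 estimated at a number 2.5 percentage points lower from compound 2 to compound 3 (within the scatter), within the scatter in either direction. Compound 3 is therefore expected near 85%, with a range from 70% to 100%.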

Compound 3, largest response reached (reported as percent of maximum), in percent of the reference or control that the assay uses: 84.5%
Estimate against measurement, compound 3: 0.5 percentage points above; the range from low to high includes it.
By their numbers in this assay, from the lowest: compound 1; then compounds 3 and 2 (each within the scatter of the next).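

Within the data shown here, the change from propylcarbonyl to isobutylcarbonyl gives the first reading at this saturated chain carbon. In this assay the step reads a number 3 percentage points lower from compound 2 to compound 3 (within the scatter), so methyl in place of hydrogen here leaves the maximal response unchanged within the scatter. Nothing in hand bears on a cause for this result.

Still open, on these data alone, is how a longer chain, a phenyl group or an amine on this saturated chain carbon would read in this assay. As far as these compounds go, whether the methyl step carries over to another core is also open.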